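Vinyl sulfone series: from compound 3 to compound 4

The source may hold more compounds than are shown below. What is called first, only, known or untested is meant among the compounds shown, and "the series" means these compounds.

Measured compounds:
compound 1, `COc1ccc(CS(=O)(=O)/C=C/c2c(F)cc(F)cc2F)cc1N`, 800 nM
compound 2, `COc1ccc(CS(=O)(=O)/C=C/c2cc(F)c(F)cc2F)cc1N`, 15000 nM
compound 3, `COC(=O)C(Nc1cc(CS(=O)(=O)/C=C/c2c(OC)cc(OC)cc2OC)ccc1OC)c1ccc(Cl)cc1`, 200 nM

These three compounds were tested in a functional assay on K562 cells (Homo sapiens) for cytotoxicity, read by trypan blue exclusion, with a stated time of 96 h; on this read-out lower numbers stand for stronger inhibition and higher numbers for weaker inhibition. Compound 1 gives 800 nM and compound 2 gives 15000 nM, so the two differ well beyond the scatter of the method. Compound 3 gives 200 nM, the lowest number of the three: its nearest neighbour is compound 1, and compound 2 lies furthest away.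

Compound 4, `COc1ccc(C(Nc2cc(CS(=O)(=O)/C=C/c3c(OC)cc(OC)cc3OC)ccc2OC)C(=O)O)cc1`, has not yet been measured in this assay. It differs from compound 3 in one place: carboxy(4-methoxyphenyl)methyl in place of (4-chlorophenyl)(methoxycarbonyl)methyl on a nitrogen on an aromatic ring. The rest of the structure, including the vinyl sulfone and the trimethoxyphenyl end, is unchanged. Among the measured compounds shown here, no measured pair in this set shows the effect of such a change, so the expectation rests only on the value of compound 3 itself. The expected step from compound 3 to compound 4 is a 2.5-fold higher number from compound 3 to compound 4 (0.40 log units; beyond the scatter), a modest move toward a higher number that may still fall within the scatter. Compound 4 is therefore estimated at 500 nM, with a range from 150 nM to 2000 nM.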

Compound 4, half-maximal inhibitory concentration: 15 nM
The estimate for compound 4 lay 33-fold (1.52 log units) above the measured number, and the stated range ends above it.
By their numbers in this assay, from the lowest: compound 4; then compound 3; then compound 1; then compound 2.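

In this assay, among the compounds shown here, putting carboxy(4-methoxyphenyl)methyl in place of (4-chlorophenyl)(methoxycarbonyl)methyl on a nitrogen on an aromatic ring gives a 13-fold lower number from compound 3 to compound 4 (1.12 log units; beyond the scatter), so the read-out is clearly sensitive to what this nitrogen carries, something the earlier compounds, with no pair differing in one place, could not show. The change is also a double one: within a group of unchanged heavy-atom count, a methoxy group replaces the chlorine on the aromatic ring, and a carboxylic acid replaces the methyl ester, bringing a hydrogen-bond donor that the leaving group lacks. Nothing available here explains why the number falls by so much.

Going by these compounds, what remains open is which of the two exchanges carries the step, or whether it takes both, a question that the pairing of the carboxylic acid with a 4-chlorophenyl group, or of the methyl ester with a 4-methoxyphenyl group, would settle. On these data alone, it is also open how far the step extends to other groups at this place, such as a primary amide or a tetrazole in place of the carboxylic acid, or a 4-fluorophenyl ring in place of the 4-methoxyphenyl ring.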